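The source may hold more compounds than are shown below. What is called first, only, known or untested is meant among the compounds shown, and "the series" means these compounds.

Measured in an ADME assay on J774.A1 cells (Mus musculus) for cytotoxicity, read by MTT assay, with a stated time of 48 h; on this read-out lower numbers stand for higher toxicity in this test and higher numbers for lower toxicity in this test:
- Compound 1 `COC(=O)c1c([N+](=O)[O-])noc1-c1ccccc1`: "not determined" (no result reported)
- Compound 2 `COC(=O)c1c([N+](=O)[O-])noc1-c1ccc(Cl)cc1`: "not determined" (no result reported)
- Compound 3 `COC(=O)c1c([N+](=O)[O-])noc1-c1ccccc1Cl`: 80100 nM

Among the measured compounds shown here, only one of these three compounds has a number. Compound 3 gives 80100 nM, while compound 1 and compound 2 have no reported result. For the measured compounds named here, compound 3 therefore cannot be ranked against anything, and the series offers no measured step showing how a change in structure moves this read-out.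

The next compound to be tested is compound 4 `COC(=O)c1c([N+](=O)[O-])noc1-c1ccc(Cl)cc1Cl`. It differs from compound 3 by one substitution: chloro in place of hydrogen on an aromatic carbon. The new chloro sits meta to a chloro group and para to a large group.

Going by the values given here, with no measured step as a guide, the expectation in this assay is cautious: a small move towards lower numbers, which would mean somewhat higher toxicity in this test, and nothing beyond the usual scatter. The expected change is a 1.3-fold lower number from compound 3 to compound 4 (0.13 log units; within the scatter). The estimate for compound 4 is 60000 nM, with an expected range from 25000 nM to 130000 nM.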

Compound 4, half-maximal cytotoxic concentration: 19700 nM
The estimate for compound 4 lay 3.0-fold (0.48 log units) above the measured number; measured number outside the range, below it.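

In this assay, among the compounds shown here, placing a chloro in place of hydrogen on the aromatic carbon meta to a chloro group and para to a large group gives a 4.1-fold lower number from compound 3 to compound 4 (0.61 log units; beyond the scatter), which is the first measured sign that this position can move the read-out. The shift is beyond the usual scatter and points towards higher toxicity in this test, although it is a single step on a single scaffold. Nothing available explains why the number falls.

From the compounds shown here alone, the steps involving compound 1 and compound 2 cannot be read, so it remains unknown whether this chloro would have an effect of the same size without the other chloro group present. Also open, going by these compounds, is whether a fluoro, a methoxy group or an amine at this same position would shift the number in the same direction.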